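This account rests on a few compounds, and the source may have more. Where it says the series, first, only, none or still open, it means among the compounds named here.

In a functional assay on NCI-H1975 cells (Homo sapiens) for antiproliferative activity, with a stated time of 72 h (a higher number here means a weaker inhibitor of growth, a lower number a stronger inhibitor of growth), compound 2 (`CN(Cc1ccccc1)C(=O)c1cc(Cl)c(O)cc1O`) gives 35500 nM. Compound 1 (`COc1ccc(CN(C)C(=O)c2cc(Cl)c(O)cc2O)cc1OC`) gives 33400 nM. For the measured compounds named here, these two numbers lie within the usual scatter of each other, so compound 2 stands level with the only other measured compound. Compound 3 (`COc1ccc(CN(C)C(=O)c2cc(Cl)c(O)cc2O)cc1`) has not yet been measured. It differs from compound 2 in one place: methoxy in place of hydrogen on an aromatic carbon. In plain terms, it has methoxy in place of hydrogen on an aromatic carbon, para to a large group. Going by the values given here, no measured pair shows this exact change, so there is no direct precedent to go on. Among the compounds with values here, the only guide is the close agreement between the two measured values, and the expectation is therefore for no step beyond the scatter in this assay. The estimated step is small: a 1.1-fold lower number from compound 2 to compound 3 (0.05 log units; within the scatter). For compound 3, the expected value is 32000 nM, with an estimated range of 16000 nM to 60000 nM.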

Compound 3, concentration for 50% growth inhibition: 16700 nM
For compound 3 the middle estimate is 1.9-fold (0.28 log units) above the measured one, within the range that was stated.
By their numbers in this assay, from the lowest: compounds 3, 1 and 2 (each within the scatter of the next, the first and the last beyond it).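

In this assay, for the compounds shown here, this is the first sign that the position responds to a change: methoxy in place of hydrogen on an aromatic carbon, para to a large group, gives a 2.1-fold lower number from compound 2 to compound 3 (0.33 log units; beyond the scatter), a modest step only just past the usual scatter. Going by these compounds alone, the other single change reads differently, since hydrogen in place of methoxy on an aromatic carbon gives a 2.0-fold lower number from compound 1 to compound 3 (0.30 log units; within the scatter), so the methoxy that compound 1 carries in addition to the one in compound 3 shows no effect that can be told apart from the scatter. No outside measurement is available to explain the step.

As far as these compounds go, it remains open whether other groups at this place, such as hydroxy, fluoro or an amine, would give a step of similar size. From the compounds shown here alone, it is also open whether a step this close to the scatter would hold up on repeat measurement.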